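The source may hold more compounds than are shown below. What is called first, only, known or untested is meant among the compounds shown, and "the series" means these compounds.

Working notes on the sulfonyl-aryl series.

Compound 3, `O=S(=O)(c1cc(F)cc(F)c1)c1cnc2cc(F)ccc2c1-c1cccc(Cl)c1`, stands at the lowest number of the three measured compounds in an ADME assay on microsomes from liver (Homo sapiens) for metabolic stability, tested at 2.5 uM; a higher number here means faster removal of the compound, a lower number slower removal: compound 3 gives 0.22 mL/min. Compound 2, `N#Cc1cccc(S(=O)(=O)c2cnc3cc(F)ccc3c2-c2cccc(Cl)c2)c1`, gives 0.99 mL/min, and compound 1, `COc1cccc(S(=O)(=O)c2cnc3cc(F)ccc3c2-c2cccc(Cl)c2)c1`, gives 2.97 mL/min. For the measured compounds named here, the measured steps all point the same way: a 3.0-fold lower number from compound 1 to compound 2 (0.48 log units; beyond the scatter), a 14-fold lower number from compound 1 to compound 3 (1.13 log units; beyond the scatter) and a 4.5-fold lower number from compound 2 to compound 3 (0.65 log units; beyond the scatter), so every exchange of the group on the sulfonyl sulfur so far has moved the number by a modest or large amount, and the change into compound 3 is the one step beyond the scatter nearest to the change considered here.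

Compound 4 is `O=S(=O)(c1ccc(F)c(F)c1)c1cnc2cc(F)ccc2c1-c1cccc(Cl)c1`. Its difference from compound 3 is 3,4-difluorophenyl in place of 3,5-difluorophenyl on a sulfonyl sulfur. Going by the values given here, both bearing steps (a 4.5-fold lower number from compound 2 to compound 3 (0.65 log units; beyond the scatter), a 14-fold lower number from compound 1 to compound 3 (1.13 log units; beyond the scatter)) swap whole groups of differing atom make-up; no measured step keeps the same atoms and only rearranges them, so the expectation is weaker. With the same atoms joined differently on the same sulfonyl sulfur, a step no larger than the scatter, or a small rise, is expected. Compound 4 is therefore estimated at 0.32 mL/min, in the range 0.12 mL/min to 0.85 mL/min, which would mean an expected step of a 1.5-fold higher number from compound 3 to compound 4 (0.16 log units; within the scatter).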

Compound 4, intrinsic clearance in a liver preparation (reported as CLH), per the amount of preparation that the assay uses: 0.38 mL/min
Estimate against measurement, compound 4: 1.2-fold (0.07 log units) below; the range from low to high includes it.
By their numbers in this assay, from the lowest: compounds 3 and 4 (each within the scatter of the next); then compound 2; then compound 1.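

Working notes, continued. In this assay, for the compounds shown here, the step with the same atoms rearranged on the sulfonyl sulfur is a 1.7-fold higher number from compound 3 to compound 4 (0.24 log units; within the scatter) and is the first change at this place that stays within the scatter, so compound 3 and compound 4 cannot be put in order. The low numbers are also not confined to the 3,5-difluorophenyl arrangement, since 3,4-difluorophenyl still gives a 2.6-fold lower number from compound 2 to compound 4 (0.42 log units; beyond the scatter) and a 7.8-fold lower number from compound 1 to compound 4 (0.89 log units; beyond the scatter), both beyond the scatter, so among these four compounds both difluorophenyl groups stand apart from the 3-cyanophenyl and 3-methoxyphenyl groups. Nothing at hand gives a reason for these numbers or for the small size of the rearrangement step.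

As far as these compounds go, what remains open is whether the low numbers need two fluorines at all, as a phenyl carrying a single fluorine, or an unsubstituted phenyl, would show. From the compounds shown here alone, it is equally open how far this place tolerates a different kind of group, such as a phenyl carrying an amine or a carboxylic acid, or a longer alkyl chain on the sulfonyl sulfur in place of the aromatic ring.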